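A few compounds are considered here, and "the series" means these few. Any claim that something is new, unique, unknown or untested is made for them only; others in the source may bear on it.

Four compounds share one scaffold and differ at two points. Compound 1 `Cc1nn(-c2ccccc2)c(Oc2ccc(-c3nc4cc([N+](=O)[O-])ccc4[nH]3)cc2)c1/C=N/NC(N)=O` and compound 2 `Cc1nn(-c2ccccc2)c(Oc2ccc(-c3nc4cc([N+](=O)[O-])ccc4[nH]3)cc2)c1/C=N/NC(N)=S` carry a nitro group on the shared core; compound 3 `Cc1nn(-c2ccccc2)c(Oc2ccc(-c3nc4cc(C(N)=O)ccc4[nH]3)cc2)c1/C=N/NC(N)=O` and compound 4 `Cc1nn(-c2ccccc2)c(Oc2ccc(-c3nc4cc(C(N)=O)ccc4[nH]3)cc2)c1/C=N/NC(N)=S` carry a carbamoyl group there instead. The difference between the two cores is carbamoyl in place of nitro on an aromatic carbon.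

In a functional assay on HeLa cells (Homo sapiens) for cytotoxicity, read by sulforhodamine B assay, with a stated time of 48 h (on this read-out lower numbers stand for stronger inhibition of growth and higher numbers for weaker inhibition of growth), compound 1 gives 11700 nM. Compound 2 gives 6600 nM. The change between them is a group of 3 heavy atoms (1 carbon, 1 nitrogen, 1 sulfur; no ring) in place of a group of 3 heavy atoms (1 carbon, 1 nitrogen, 1 oxygen; no ring), on an amine nitrogen, and it made a step of a 1.8-fold lower number from compound 1 to compound 2 (0.25 log units; within the scatter).

For compound 3 the entry in this assay reads "not determined" (no result reported), so there is no single number to start from. Compound 4 differs from compound 3 by a group of 3 heavy atoms (1 carbon, 1 nitrogen, 1 sulfur; no ring) in place of a group of 3 heavy atoms (1 carbon, 1 nitrogen, 1 oxygen; no ring), on an amine nitrogen, the same change as that from compound 1 to compound 2, at the same kind of position.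

Going by the values given here, since the one measured example of this change stayed within the scatter, compound 4 is expected to land near the range set by compound 1 and compound 2 in this assay. For compound 4 the estimate is 8000 nM, with a likely spread from 2000 nM to 40000 nM. The spread is kept wide: the carbamoyl core itself has no measured value to anchor it.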

Compound 4, concentration for 50% growth inhibition: 14600 nM
Compound 4: middle estimate off by 1.8-fold (0.26 log units), on the low side, and the stated range covers the measured number.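

Carbamoyl in place of nitro on an aromatic carbon, with the sulfur-containing group kept on the amine nitrogen, makes a step of a 2.2-fold higher number from compound 2 to compound 4 (0.34 log units; beyond the scatter) in this assay, so growth inhibition is modestly weaker with carbamoyl in this one pair. This single pair does not show that the same step would appear with the oxygen-containing group, and the steps that involve compound 3 cannot be read, as it has no result. Going by these compounds, for the same reason, it remains unknown whether the sulfur-for-oxygen change behaves on the carbamoyl core as it did on the nitro core, where it made a step of a 1.8-fold lower number from compound 1 to compound 2 (0.25 log units; within the scatter); no measurement here explains either step.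

The compounds shown leave open how other groups on that aromatic carbon, such as an amine, a nitrile or a carboxylic acid, would compare with nitro and carbamoyl. They also leave open whether any such group would give stronger growth inhibition than compound 2 at 6600 nM.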